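The source may hold more compounds than are shown below. What is called first, only, known or untested is meant among the compounds shown, and "the series" means these compounds.

Going by the values given here, the two compounds measured so far share one core and differ only in a single group on the aromatic ring. Compound 1 `Cc1ccc([B-]2(c3ccccc3)[NH2+]CCO2)cc1` carries a methyl there, and in an assay on HEK293 cells for inhibition of transient receptor potential cation channel subfamily V member 6 (Homo sapiens), read by FLIPR, with a stated time of 5 min (on this read-out lower numbers stand for stronger inhibition and higher numbers for weaker inhibition), compound 1 gives 12900 nM. Compound 2 `Brc1ccc([B-]2(c3ccccc3)[NH2+]CCO2)cc1` carries a bromo in that place, and in this assay compound 2 gives 9800 nM. Among the compounds with values here, the only measured step, a 1.3-fold lower number from compound 1 to compound 2 (0.12 log units; within the scatter), stays within the scatter, so the two numbers cannot be told apart with confidence. Of the two numbers, compound 2 gives the smaller one, with compound 1 nearest, and the gap between them lies within the scatter.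

Compound 3 `Ic1ccc([B-]2(c3ccccc3)[NH2+]CCO2)cc1` is the next member of the series. It differs from compound 2 in one place: iodo in place of bromo on an aromatic carbon. Within the data shown here, the one step that bears on this change is a 1.3-fold lower number from compound 1 to compound 2 (0.12 log units; within the scatter), which exchanged one group at the same place for another and moved the number within the scatter. A further exchange of halogen at that place is therefore expected to move the number little, if at all, beyond the scatter, and the estimated step is a 1.2-fold lower number from compound 2 to compound 3 (0.09 log units; within the scatter). Compound 3 is expected to give about 8000 nM in this assay, within a range from 3000 nM to 25000 nM.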

Compound 3, half-maximal inhibitory concentration: 5200 nM
The estimate for compound 3 lay 1.5-fold (0.19 log units) above the measured number; measured number inside the range.
By their numbers in this assay, from the lowest: compounds 3, 2 and 1 (each within the scatter of the next, the first and the last beyond it).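

In this assay, going by these compounds alone, iodo in place of methyl gives a 2.5-fold lower number from compound 1 to compound 3 (0.39 log units; beyond the scatter) and this is the only step among the three compounds that lies beyond the scatter, which shows that the group at this place, on an aromatic carbon para to a large group, can shift the number measurably, though modestly. Iodo in place of bromo gives a 1.9-fold lower number from compound 2 to compound 3 (0.28 log units; within the scatter) and so stays within the scatter, which means that compound 2 and compound 3 cannot be told apart with confidence and that a clear separation appears only between the two ends of the set, methyl and iodo. Nothing measured on these compounds accounts for that separation, so no cause can be named for it.

The compounds shown carry only methyl, bromo or iodo at this place, so it remains open what an amine, a carboxylic acid, a methoxy group or a longer chain would do there. Also open, on these data alone, is whether a change elsewhere on the shared core would move the number further than any step seen here.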